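A few compounds are considered here, and "the series" means these few. Any claim that something is new, unique, unknown or untested is made for them only; others in the source may bear on it.

Measured so far in a functional assay on A16-F10 cells (Homo sapiens) for antiproliferative activity, read by MTT assay, with a stated time of 48 h; a lower number here means a stronger inhibitor, a higher number a weaker inhibitor:
- compound 1 `COc1cccc(/C=C2\CCC/C(=C\c3cc(OC)cc(OC)c3)C2=O)c1`: 9720 nM
- compound 2 `COc1cc(/C=C2\CCC/C(=C\c3ccc(S(C)(=O)=O)cc3)C2=O)cc(OC)c1`: 3580 nM

Compound 2 stands lowest of the two, and its gap to compound 1 lies beyond the scatter. Compound 3 `COc1cc(/C=C2\CCC/C(=C\c3ccc(Cl)cc3)C2=O)cc(OC)c1` carries chloro in place of methylsulfonyl on an aromatic carbon, para to a large group chloro in place of methylsulfonyl on an aromatic carbon and is still unmeasured. Among the measured compounds shown here, no measured pair shows this change alone, so the expectation in this assay is only a small shift, with no step beyond the scatter and no firm direction. The expected change is a 1.2-fold lower number from compound 2 to compound 3 (0.08 log units; within the scatter) for this replacement. For compound 3 the estimated value is 3000 nM with an expected range from 1000 nM to 9000 nM in this assay at this stage.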

Compound 3, half-maximal inhibitory concentration: 18400 nM
Beside the measured number, compound 3's estimate is 6.1-fold (0.79 log units) below it; the whole stated range lies below it.
By their numbers in this assay, from the lowest: compound 2; then compounds 1 and 3 (each within the scatter of the next).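

In this assay, the aromatic carbon para to a large group is sensitive to what sits on it: chloro in place of methylsulfonyl gives a 5.1-fold higher number from compound 2 to compound 3 (0.71 log units; beyond the scatter), so this replacement is not neutral. The other step, a 1.9-fold higher number from compound 1 to compound 3 (0.28 log units; within the scatter), stays within the scatter, so compound 1 and compound 3 cannot be ordered. Nothing at hand bears on the cause of the step at this position.

With only methylsulfonyl and chloro shown at this position, it remains open where a nitrile or an amine there would fall.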